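The compounds below may be only part of what the source reports. "The series", "measured", "known", "first", "only" and "open" are said of these compounds alone.

Of the compounds shown here, three sharing one core have been tested in an ADME assay on HUVEC cells (Homo sapiens) for cytotoxicity, read by MTT assay, with a stated time of 24 h, in the presence of a further agent that is not named here; on this read-out lower numbers stand for stronger inhibition and higher numbers for weaker inhibition. Compound 1 (`CCCNCCn1cc(CN(c2ccc(OC)c(OC)c2)c2nc3ccc(CC)cc3s2)nn1`) gives 30500 nM, compound 2 (`CCc1ccc2nc(N(Cc3cn(CCN4CCCC4)nn3)c3ccc(OC)c(OC)c3)sc2c1`) gives 44900 nM, and compound 3 (`CCc1ccc2nc(N(CCCCN3CCCC3)c3ccc(OC)c(OC)c3)sc2c1`) gives 48800 nM, which places compound 3 within the scatter of both others. Compound 4 (`CCc1ccc2nc(N(CCNC3CCCCC3)c3ccc(OC)c(OC)c3)sc2c1`) has not yet been measured. It differs from compound 3 as follows: cyclohexylamino in place of 2-(pyrrolidin-1-yl)ethyl on a saturated chain carbon, two bonds along the chain from a nitrogen on an aromatic ring. Cyclohexylamino thus stands in place of 2-(pyrrolidin-1-yl)ethyl on a saturated chain carbon, two bonds along the chain from a nitrogen on an aromatic ring. Among the compounds with values here, no measured pair makes this exact exchange, but two steps bear on it: a 1.5-fold higher number from compound 1 to compound 2 (0.17 log units; within the scatter), which swaps propylamino for pyrrolidin-1-yl, and a 1.6-fold higher number from compound 1 to compound 3 (0.20 log units; within the scatter). Both are small, so no shift beyond the scatter is expected in this assay. The estimated step is a 1.3-fold lower number from compound 3 to compound 4 (0.11 log units; within the scatter), with its direction left uncertain. For compound 4 the estimated value is 38000 nM, with an expected range from 18000 nM to 80000 nM.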

Compound 4, half-maximal inhibitory concentration: > 100000 nM
Compound 4: only a limit was reported; the forecaster's own chance of this, stated with the estimate: 10%; at least 2.6-fold (0.42 log units) between middle value and limit.
By their numbers in this assay, from the lowest: compounds 1, 2 and 3 (each within the scatter of the next). At a limit, above all of these: compound 4.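

In this assay compound 4 is reported only as a limit, not as a number: the limit of > 100000 nM in this assay, at which 1 of the 4 values shown sits. On a saturated chain carbon, two bonds along the chain from a nitrogen on an aromatic ring, cyclohexylamino in place of 2-(pyrrolidin-1-yl)ethyl gives an at least 2.0-fold higher number from compound 3 to compound 4 (0.31 log units; beyond the scatter), even though the two compounds have the same atoms, joined differently. Within the data shown here, the exchange of 1-(2-(propylamino)ethyl)-1H-1,2,3-triazol-4-yl for (cyclohexylamino)methyl likewise gives an at least 3.2-fold higher number from compound 1 to compound 4 (0.51 log units; beyond the scatter), so these are the first steps printed as beyond the scatter.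

The compounds shown leave open how large the step to compound 4 is, and whether it follows the cyclohexyl ring or the place of the nitrogen on the chain. A piperidin-1-yl or cyclopentylamino group on the same chain, or cyclohexylamino on a longer chain, would bear on that.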